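Stepwise alkyl growth in a cytotoxicity series

The source may report more compounds than this note shows. Statements on the series, on what has been measured and on what is new or still open speak of the compounds shown alone.

Measured so far:
compound 1 `Cc1ccc(-n2nc(-c3ccc(C(F)(F)F)cc3O)nc2-c2ccccc2O)cc1` — 102%
compound 2 `CCc1ccc(-n2nc(-c3ccc(C(F)(F)F)cc3O)nc2-c2ccccc2O)cc1` — 107%

In a functional assay on PC-12 cells (Rattus norvegicus) for cytotoxicity, read by MTT assay, with stated times of 2 h and 24 h, tested at 10 uM (a higher number here means a stronger effect of the compound at the concentration tested, a lower number a weaker effect), compound 2 gives 107%. For the measured compounds named here, only two numbers are known in this assay, and the single neighbour of compound 2, compound 1, sits within the scatter of it; the step of a number 5 percentage points higher from compound 1 to compound 2 (within the scatter) changes nothing that can be read as real.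

Compound 3 `CC(C)c1ccc(-n2nc(-c3ccc(C(F)(F)F)cc3O)nc2-c2ccccc2O)cc1` has not been measured in this assay. It differs from compound 2 by methyl in place of hydrogen on a saturated chain carbon bound to an aromatic carbon and a saturated chain carbon.

Going by the values given here, the one measured step that bears on this change is a number 5 percentage points higher from compound 1 to compound 2 (within the scatter), which also put a methyl onto the same chain and did not leave the scatter. Among the compounds with values here, no other step is known. The expected step is therefore of the same size, with no change beyond the scatter: a number 2 percentage points lower from compound 2 to compound 3 (within the scatter). Compound 3 is estimated at 105%, with a range from 93% to 117%.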

Compound 3, a percentage reported as activity, at one concentration (the size of the read-out at that concentration, not a potency): 108%
The estimate for compound 3 lay 3 percentage points below the measured number; low and high end bracket the measured number.
By their numbers in this assay, from the lowest: compounds 1, 2 and 3 (each within the scatter of the next).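

In this assay the change from 4-ethylphenyl to 4-isopropylphenyl, which makes the chain branched at the saturated carbon bound to the aromatic carbon, shows a number 1 percentage points higher from compound 2 to compound 3 (within the scatter) and thus stays as unreadable as the earlier unbranched growth. Taken across the whole series, isopropyl in place of methyl on the aromatic carbon shows a number 6 percentage points higher from compound 1 to compound 3 (within the scatter) so even the widest alkyl difference among these compounds does not separate them in this read-out. Nothing available gives a reason for this absence of separation at this position.

The compounds shown leave open whether any group on this aromatic carbon moves the read-out beyond the scatter, with a longer chain, a tert-butyl group or an amine as the obvious contrasts to these small alkyl groups. They also leave open whether a change elsewhere on the shared core would do so.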